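Adding a methyl to the chain of compound 1

The source may hold more compounds than are shown below. What is called first, only, known or untested is meant among the compounds shown, and "the series" means these compounds.

Measured so far:
- compound 1 `CC(CCCCC(=O)NO)Nc1c(Nc2ccc(C(F)(F)F)cc2)c(=O)c1=O` gives 20000000 nM in a physicochemical assay for solubility, with a stated time of 24 h, tested at 30 mg/mL; on this read-out higher numbers stand for higher solubility and lower numbers for lower solubility
- compound 2 `CCC(CCCCC(=O)NO)Nc1c(Nc2ccc(C(F)(F)F)cc2)c(=O)c1=O` gives 25000000 nM in this assay

Compound 1 can be compared only with compound 2, and the two values lie within the scatter of each other. Compound 3 `CC(C)(CCCCC(=O)NO)Nc1c(Nc2ccc(C(F)(F)F)cc2)c(=O)c1=O` has not yet been measured. It differs from compound 1 by one change (methyl in place of hydrogen on a saturated chain carbon bound to a nitrogen on an aromatic ring and two saturated chain carbons). Going by the values given here, one measured step bears on it (a 1.3-fold higher number from compound 1 to compound 2 (0.10 log units; within the scatter)). That step also puts methyl in place of hydrogen, but on a chain carbon two bonds along the chain from a nitrogen on an aromatic ring. Among the compounds with values here, no measured compound carries the new methyl at the place it occupies in compound 3, so the evidence is thin. No step beyond the scatter is expected in this assay. The expected step is a 1.1-fold higher number from compound 1 to compound 3 (0.04 log units; within the scatter). For compound 3 the estimated value is 22000000 nM, with an expected range from 10000000 nM to 45000000 nM.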

Compound 3, solubility: 30000000 nM
The estimate for compound 3 lay 1.4-fold (0.13 log units) below the measured number; the range from low to high includes it.
By their numbers in this assay, from the lowest: compounds 1, 2 and 3 (each within the scatter of the next).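

Methyl in place of hydrogen on a saturated chain carbon bound to a nitrogen on an aromatic ring and two saturated chain carbons gives a 1.5-fold higher number from compound 1 to compound 3 (0.18 log units; within the scatter) in this assay, so this position takes the added methyl with no step beyond the scatter. Going by these compounds alone, the earlier compounds showed this only for a methyl two bonds along the chain from that nitrogen; the same reading now holds at the carbon bound to the nitrogen, though on the single pair of compound 1 and compound 3. No measured evidence speaks to the reason for this result.

Going by these compounds, whether another group at this carbon, such as an amine, a carboxylic acid or a longer chain, would give a step beyond the scatter remains open. So does the outcome of the same methyl change elsewhere on the shared core.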